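Branching a Side Chain in Three Related Agonists

The source may report more compounds than this note shows. Statements on the series, on what has been measured and on what is new or still open speak of the compounds shown alone.

Three measured compounds share one core and differ only in the group attached to a carbonyl carbon. Compound 1 `CCCOC(=O)N1CCC(Oc2ncnc3c2CCN3c2ccc(S(C)(=O)=O)cc2F)CC1` carries a propoxy group there, and in a functional assay on CHO-K1 cells with Glucose-dependent insulinotropic receptor (Homo sapiens) as the target, read by a luciferase reporter, with a stated time of 5 h (a lower number here means a smaller maximal response, a higher number a larger maximal response), compound 1 reaches 111%. Compound 2 `CC(C)COC(=O)N1CCC(Oc2ncnc3c2CCN3c2ccc(S(C)(=O)=O)cc2F)CC1` differs from compound 1 by methyl in place of hydrogen on a saturated chain carbon bound to two saturated chain carbons; in this assay compound 2 reaches 94%, a step of a number 17 percentage points lower from compound 1 to compound 2 (beyond the scatter). Compound 3 `CCSC(=O)N1CCC(Oc2ncnc3c2CCN3c2ccc(S(C)(=O)=O)cc2F)CC1` differs from compound 1 by ethylsulfanyl in place of propoxy on a carbonyl carbon, and in this assay compound 3 reaches 128%, which gives a number 17 percentage points higher from compound 1 to compound 3 (beyond the scatter) and a number 34 percentage points higher from compound 2 to compound 3 (beyond the scatter).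

Compound 4 `CC(C)SC(=O)N1CCC(Oc2ncnc3c2CCN3c2ccc(S(C)(=O)=O)cc2F)CC1` has not yet been measured. It differs from compound 3 by methyl in place of hydrogen on a saturated chain carbon bound to a saturated chain carbon and a sulfur. Going by the values given here, this is the same kind of change as the one from compound 1 to compound 2, but the methyl now enters on a saturated chain carbon bound to a saturated chain carbon and a sulfur rather than on one bound to two saturated chain carbons. Because the earlier branching gave a number 17 percentage points lower from compound 1 to compound 2 (beyond the scatter), the expected step is a number 18 percentage points lower from compound 3 to compound 4 (beyond the scatter). Among the compounds with values here, only one such step supports this, so the range is wide. Compound 4 is estimated to reach 110% in this assay, between 90% and 130%.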

Compound 4, largest response reached (reported as percent of maximum), in percent of the reference or control that the assay uses: 138%
Compound 4: the middle estimate sits 28 percentage points below what was measured, and the stated range ends below it.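

Adding the same methyl does not give the same result on the two cores: the same change on two cores in this assay, a number 17 percentage points lower (beyond the scatter) from compound 1 to compound 2 and a number 10 percentage points higher (within the scatter) from compound 3 to compound 4, 27 percentage points apart, beyond the scatter of two such steps

So a branching step seen on the propoxy compound cannot simply be carried over to the ethylsulfanyl compound, and the new step itself reads a number 10 percentage points higher from compound 3 to compound 4 (within the scatter). In this assay, replacing the whole group on the carbonyl carbon gives a number 44 percentage points higher from compound 2 to compound 4 (beyond the scatter) and a number 27 percentage points higher from compound 1 to compound 4 (beyond the scatter), yet one pair per core cannot show why the methyl behaves differently or whether the same split would appear with other changes.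

As far as these compounds go, how the maximal response moves with a longer chain such as butylsulfanyl, or with a further branched tert-butylsulfanyl group, stays open. So does what an amine on the carbonyl carbon would give in place of the oxygen and sulfur links seen here.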